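This account rests on a few compounds, and the source may have more. Where it says the series, first, only, none or still open, it means among the compounds named here.

Measured so far in a functional assay on NCI-H460 cells (Homo sapiens) for antiproliferative activity, read by sulforhodamine B assay, with a stated time of 72 h (on this read-out lower numbers stand for stronger inhibition and higher numbers for weaker inhibition), are two compounds:
- compound 1 `Cc1cc(C)nc(NS(=O)(=O)c2ccc(Nc3nncc4ccccc34)cc2)n1` gives 0.8 nM
- compound 2 `O=S(=O)(Nc1ncccn1)c1ccc(Nc2nncc3ccccc23)cc1` gives 33 nM

Compound 2 holds the higher of these two numbers, and the gap to compound 1 lies beyond the scatter. The next compound, compound 3 `O=S(=O)(Nc1nccs1)c1ccc(Nc2nncc3ccccc23)cc1`, differs from compound 2 as follows: 1,3-thiazol-2-yl in place of pyrimidin-2-yl on a sulfonamide nitrogen. In words, 1,3-thiazol-2-yl stands in place of pyrimidin-2-yl on a sulfonamide nitrogen.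

Among the compounds with values here, one measured step bears on this change, at the same nitrogen: a 41-fold higher number from compound 1 to compound 2 (1.62 log units; beyond the scatter) is large and beyond the scatter. It shows that the group there can move the number strongly, but it replaces 4,6-dimethylpyrimidin-2-yl with pyrimidin-2-yl and says nothing directly about 1,3-thiazol-2-yl. Within the data shown here, no measured compound carries that group, so the direction is uncertain. Since compound 1 reaches 0.8 nM with a different group on that nitrogen, a modest move towards a lower number is expected, smaller than the measured step. The estimated change is a 1.7-fold lower number from compound 2 to compound 3 (0.22 log units; within the scatter) in this assay and could fall on either side. For compound 3 the estimated value is 20 nM with an expected range from 3 nM to 130 nM.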

Compound 3, half-maximal inhibitory concentration: 39 nM
Compound 3: the middle estimate sits 2.0-fold (0.29 log units) below what was measured; the range from low to high includes it.
By their numbers in this assay, from the lowest: compound 1; then compounds 2 and 3 (each within the scatter of the next).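

In this assay the step from the six-membered pyrimidin-2-yl to the five-membered 1,3-thiazol-2-yl on a sulfonamide nitrogen is a 1.2-fold higher number from compound 2 to compound 3 (0.07 log units; within the scatter) and so does not separate the two groups, which shows that this position tolerates a change of ring size and of hetero atoms with no measurable consequence in this pair. The gap to compound 1 is of the same order for both groups, with a 49-fold higher number from compound 1 to compound 3 (1.69 log units; beyond the scatter) standing alongside a 41-fold higher number from compound 1 to compound 2 (1.62 log units; beyond the scatter), so among these three compounds only the 4,6-dimethylpyrimidin-2-yl group stands apart. Nothing measured here accounts for that separation or for the match between compound 2 and compound 3.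

The compounds shown leave open whether a single methyl, as in 4-methylpyrimidin-2-yl, is enough to reach the number of compound 1, and whether methyl groups on the 1,3-thiazol-2-yl ring would have a comparable effect. They also leave open how methoxy groups in place of the two methyl groups on the pyrimidine ring would read in this assay.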